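Halogen Exchange on the Pendant Phenyl Ring

The compounds below may be only part of what the source reports. "The series", "measured", "known", "first", "only" and "open" are said of these compounds alone.

Compound 2 `Cc1ccc(Nc2nc(SCc3cn(Cc4ccccc4Cl)nn3)nc(-c3ccc(Cl)cc3)c2C#N)cc1` is one of two measured compounds, and in a functional assay on ECa-109 cells (Homo sapiens) for inhibition, read by MTT assay, with a stated time of 72 h (on this read-out lower numbers stand for stronger inhibition and higher numbers for weaker inhibition), compound 2 gives 7540 nM. Its nearest neighbour, compound 1 `Cc1ccc(Nc2nc(SCc3cn(Cc4ccccc4Cl)nn3)nc(-c3ccc(C)cc3)c2C#N)cc1`, gives 4650 nM in this assay, and the step of a 1.6-fold higher number from compound 1 to compound 2 (0.21 log units; within the scatter) stays within the scatter. Compound 3 `Cc1ccc(Nc2nc(SCc3cn(Cc4ccccc4Cl)nn3)nc(-c3ccc(Br)cc3)c2C#N)cc1` differs from compound 2 in one place: bromo in place of chloro on an aromatic carbon. Within the data shown here, the one measured step at this position, a 1.6-fold higher number from compound 1 to compound 2 (0.21 log units; within the scatter), bears on it and was small, so no step beyond the scatter is expected in this assay. For compound 3 the expected value is 7500 nM, between 3500 nM and 16000 nM, an expected step of a 1.0-fold lower number from compound 2 to compound 3 (0.00 log units; within the scatter).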

Compound 3, half-maximal inhibitory concentration: 3090 nM
Estimate against measurement, compound 3: 2.4-fold (0.39 log units) above; measured number outside the range, below it.
By their numbers in this assay, from the lowest: compounds 3, 1 and 2 (each within the scatter of the next, the first and the last beyond it).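

In this assay, bromo in place of chloro produces a 2.4-fold lower number from compound 2 to compound 3 (0.39 log units; beyond the scatter), so this position does respond to the exchange of one halogen for another, though only modestly. Bromo and methyl, by contrast, cannot be told apart here, with a 1.5-fold lower number from compound 1 to compound 3 (0.18 log units; within the scatter). Nothing available explains why the two halogens differ. The compounds shown leave open how fluoro, methoxy or an amine at this position would read, and whether the gap between chloro and bromo would hold with other groups elsewhere on the core.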